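Replacing 2-(hydroxymethyl)-1-methylpropyl with 1-isopropylhexyl in compound 3

A few compounds are considered here, and "the series" means these few. Any claim that something is new, unique, unknown or untested is made for them only; others in the source may bear on it.

Measured in a functional assay on HL-60 cells (Homo sapiens) for cytotoxicity, read by WST assay, with a stated time of 48 h (on this read-out higher numbers stand for weaker inhibition and lower numbers for stronger inhibition), so far:
- compound 1 `COc1cc(C(c2ccc(O)c(OC)c2)[C@@H](C)[C@@H](C)CF)ccc1O` gives 38000 nM
- compound 2 `COc1cc(C(c2ccc(O)c(OC)c2)[C@H](C)[C@@H](C)CO)ccc1O` gives > 100000 nM (a limit, not a number)

Compound 2 gives only a limit and no number (the limit of > 100000 nM in this assay, at which 1 of the 2 values shown sits). Compound 3 `CCCCC[C@H](C(C)C)C(c1ccc(O)c(OC)c1)c1ccc(O)c(OC)c1` has 1-isopropylhexyl in place of 2-(hydroxymethyl)-1-methylpropyl on a saturated chain carbon bound to two aromatic carbons. The entering group has no oxygen.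

For the measured compounds named here, one measured step bears on this change (an at least 2.6-fold higher number from compound 1 to compound 2 (0.42 log units; beyond the scatter)). It brings in the same 2-(hydroxymethyl)-1-methylpropyl that compound 3 gives up, in place of 2-(fluoromethyl)-1-methylpropyl, and the number rises beyond the scatter. Going by the values given here, this is a single pair, and no measured compound carries a group like 1-isopropylhexyl, so the size of the next step is poorly fixed. Its direction is clearer, and a move toward stronger inhibition in this assay is expected. The estimated step is (an at least 10-fold lower number from compound 2 to compound 3 (1.00 log units; beyond the scatter)) and is probably larger than the one measured. For compound 3 the expected value is 10000 nM with an estimated range from 2500 nM to 45000 nM.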

Compound 3, half-maximal inhibitory concentration: 9600 nM
For compound 3 the middle estimate is 1.0-fold (0.02 log units) above the measured one; measured number inside the range.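

In this assay, for the compounds shown here, the earlier compounds showed only a rise in the number at the saturated chain carbon bound to two aromatic carbons, whereas this change shows that the same place can also move toward stronger inhibition: replacing 2-(fluoromethyl)-1-methylpropyl with 1-isopropylhexyl gives a 4.0-fold lower number from compound 1 to compound 3 (0.60 log units; beyond the scatter). Replacing 2-(hydroxymethyl)-1-methylpropyl with 1-isopropylhexyl gives an at least 10-fold lower number from compound 2 to compound 3 (1.01 log units; beyond the scatter), but compound 2 has only a limit and no number, so the true size of this step stays unfixed: the limit of > 100000 nM in this assay, at which 1 of the 3 values shown sits. The place therefore accepts a larger chain with no oxygen, and compound 3 has the lowest number of the three compounds in this assay, with its steps to both others beyond the scatter.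

The entering 1-isopropylhexyl differs from both earlier groups in size, branching and the absence of a fluorine or oxygen atom, so the compounds shown do not separate which of these features accounts for the lower number. Also open, on these data alone, is how a longer chain such as 1-isopropyloctyl, or a chain ending in an amine or a carboxylic acid, would read in this assay.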